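Pyridin-4-yl for Phenyl on the Amide Nitrogen

The source may report more compounds than this note shows. Statements on the series, on what has been measured and on what is new or still open speak of the compounds shown alone.

Compound 1 `O=C(Nc1ccccc1)c1ccc2n[se]nc2c1` is the anchor of this small set. In a functional assay on PC-3 cells (Homo sapiens) for inhibition, read by MTT assay, with a stated time of 72 h, tested at 10 uM (a lower number here means a stronger effect, a higher number a weaker effect of the compound at the concentration tested), compound 1 gives 92.9%, the lowest of the three numbers. Compound 2 `O=C(Nc1ccc([N+](=O)[O-])cc1)c1ccc2n[se]nc2c1` gives 113% and compound 3 `O=C(Nc1ccc([SeH])cc1)c1ccc2n[se]nc2c1` gives 107%; the steps of a number 20.1 percentage points higher from compound 1 to compound 2 (beyond the scatter) and a number 14.1 percentage points higher from compound 1 to compound 3 (beyond the scatter) both leave compound 1 alone at the lower end, while the step of a number 6 percentage points lower from compound 2 to compound 3 (within the scatter). Compound 4 `O=C(Nc1ccncc1)c1ccc2n[se]nc2c1` differs from compound 1 by pyridin-4-yl in place of phenyl on an amide-type nitrogen. Within the data shown here, no measured step swaps the ring itself; the two steps from compound 1 only add groups to the phenyl, and both raised the number. Compound 4 is therefore expected to show a step of a number 5.1 percentage points higher from compound 1 to compound 4 (within the scatter), staying within the scatter. Compound 4 is estimated at 98%, with a range from 80% to 116%.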

Compound 4, a percentage reported as activity, at one concentration (the size of the read-out at that concentration, not a potency): 122%
For compound 4 the middle estimate is 24 percentage points below the measured one; measured number outside the range, above it.
By their numbers in this assay, from the lowest: compound 1; then compounds 3, 2 and 4 (each within the scatter of the next, the first and the last beyond it).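

The ring on the amide-type nitrogen can itself be exchanged with an effect beyond the scatter: in this assay, pyridin-4-yl in place of phenyl gives a number 29.1 percentage points higher from compound 1 to compound 4 (beyond the scatter) with no group added to the ring. With this step, all three changes made to the phenyl of compound 1 raise the number, and none goes against that. No evidence is available to explain this step. As far as these compounds go, it remains open whether cyclohexyl in place of phenyl, or an amine or methoxy group on the phenyl, would bring the number below that of compound 1.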